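Taking the hydroxy off the ring of compound 2

This account rests on a few compounds, and the source may have more. Where it says the series, first, only, none or still open, it means among the compounds named here.

Compound 1 `O[C@H](c1ccccn1)[C@]1(c2cccc(OC(F)(F)F)c2)C[C@@H](O)C1`: 117 mL/min/kg
Compound 2 `O[C@H](c1ccccn1)[C@]1(c2cccc(OC(F)(F)F)c2)C[C@H](O)C1`: 150 mL/min/kg

Both numbers come from an ADME assay on liver for metabolic stability, with Liver microsome (Homo sapiens) as the target, read by LC-MS, using microsomes, with a stated time of 5 h (a higher number here means faster removal of the compound, a lower number slower removal), and the two compounds stand level: the measured step is (a 1.3-fold higher number from compound 1 to compound 2 (0.11 log units; within the scatter)) and it reflects (the fact that compounds 1 and 2 differ only in the configuration as drawn). Compound 2, at (150 mL/min/kg), is therefore the starting point, with no clear separation from compound 1. Compound 3 `O[C@H](c1ccccn1)C1(c2cccc(OC(F)(F)F)c2)CCC1` has hydrogen in place of hydroxy on a saturated ring carbon. For the measured compounds named here, no measured step removes a group, so the step between compound 1 and compound 2 (a 1.3-fold higher number from compound 1 to compound 2 (0.11 log units; within the scatter)) gives only a loose guide to size. A small move to a higher number is expected, perhaps not beyond the scatter. The expected change is (a 1.2-fold higher number from compound 2 to compound 3 (0.08 log units; within the scatter)). For compound 3 the estimate in this assay is 180 mL/min/kg (expected range 105 mL/min/kg to 300 mL/min/kg).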

Compound 3, clearance: 2220 mL/min/kg
Estimate against measurement, compound 3: 12-fold (1.09 log units) below; measured number outside the range, above it.
By their numbers in this assay, from the lowest: compounds 1 and 2 (each within the scatter of the next); then compound 3.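

In this assay this ring carbon turns out to matter far more than the earlier pair suggested: hydrogen in place of hydroxy gives a 15-fold higher number from compound 2 to compound 3 (1.17 log units; beyond the scatter) and, from the other configuration, a 19-fold higher number from compound 1 to compound 3 (1.28 log units; beyond the scatter). Compound 1 and compound 2 showed only that the way the hydroxy is drawn leaves the number within the scatter, whereas having a hydroxy on this carbon at all separates both compounds from compound 3 by far more than the scatter. Nothing given here accounts for the size of this step.

The compounds shown leave open whether another group on this ring carbon, such as an amine or a methoxy group, would keep the number near that of compound 2 or let it rise toward that of compound 3. They also do not tell which part of compound 3 is removed so quickly.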